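This account rests on a few compounds, and the source may have more. Where it says the series, first, only, none or still open, it means among the compounds named here.

Measured compounds:
Compound 1 `CCc1c(Cc2ccc(Br)cc2)nc(SCc2ccc(OC)cc2)[nH]c1=O`: > 281000 nM
Compound 2 `CCc1c(Cc2cc(C)cc(C)c2)nc(SCc2ccc(OC)cc2)[nH]c1=O`: > 317000 nM

Both compounds share one core and differ only in the aryl group carried on a saturated chain carbon bound to an aromatic carbon. In an ADME assay on MT4 cells (Homo sapiens) for cytotoxicity, read by MTT assay (a higher number here means that more compound is tolerated, a lower number that less compound is tolerated), compound 1 gives > 281000 nM, which is a limit of the assay and not a number. Compound 2 gives > 317000 nM in this assay, again a limit rather than a measured value. The change a step that the two limits leave unreadable from compound 1 to compound 2 therefore cannot be sized, because the limit of > 281000 nM in this assay, at which 1 of the 2 values shown sits, and the limit of > 317000 nM in this assay, at which 1 of the 2 values shown sits, both mark the top of what was tested. So compound 2 stands at a limit, and the one other value shown stands at a limit as well.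

Compound 3 `CCc1c(Cc2cccc3ccccc23)nc(SCc2ccc(OC)cc2)[nH]c1=O` has not yet been tested. It differs from compound 2 by naphthalen-1-yl in place of 3,5-dimethylphenyl on a saturated chain carbon bound to an aromatic carbon. Within the data shown here, the only measured step bearing on this position was unreadable, so no direction beyond the scatter can be expected in this assay. Compound 3 is expected to give 300000 nM in this assay, within 150000 nM to 600000 nM. That estimate corresponds to an expected step of an at least 1.0-fold lower number from compound 2 to compound 3 (0.02 log units; that floor lies within the scatter), most likely reported again as a limit.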

Compound 3, half-maximal cytotoxic concentration: 261000 nM
For compound 3 the middle estimate is 1.1-fold (0.06 log units) above the measured one; low and high end bracket the measured number.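

Among these compounds, with naphthalen-1-yl on a saturated chain carbon bound to an aromatic carbon, compound 3 gives 261000 nM in this assay, the only true number among the three values shown at this position. Exchanging 3,5-dimethylphenyl for this group gives an at least 1.2-fold lower number from compound 2 to compound 3 (0.08 log units; that floor lies within the scatter), and exchanging 4-bromophenyl for it gives an at least 1.0-fold lower number from compound 1 to compound 3 (0.03 log units; that floor lies within the scatter), so neither step is shown to go beyond the scatter, although a second aromatic ring is now present. The step between the two earlier compounds still cannot be read, and the true size of the two new steps stays open because each of them starts from a limit: the limit of > 281000 nM in this assay, at which 1 of the 3 values shown sits; the limit of > 317000 nM in this assay, at which 1 of the 3 values shown sits.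

All three groups shown here are built on aromatic rings, so it remains open how a saturated ring such as cyclohexyl would behave at this place in this assay. Also open, on these data alone, is whether an amine or a carboxylic acid on the aryl group, or a longer chain in place of the single saturated carbon, would bring the number clearly down.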